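Replacing a basic ring with a sulfonamide on the benzylic carbon

A few compounds are considered here, and "the series" means these few. Any claim that something is new, unique, unknown or untested is made for them only; others in the source may bear on it.

Of the compounds shown here, three sharing one amide core have been measured in an ADME assay on the whole organism (Mus musculus, strain CD1), read by LC-MS, using cassette dosing, with a stated time of 24 h, at a dose of 0.4 mg/kg by the intravenous route; on this read-out higher numbers stand for a longer-lived compound and lower numbers for a shorter-lived compound. Compound 1 `Cc1cn(-c2cc(NC(=O)c3ccc(C)c(Nc4nccc(-c5ccccc5)n4)c3)cc(N3CCNCC3)c2)cn1` gives 1.19 h, compound 2 `Cc1cn(-c2cc(NC(=O)c3ccc(C)c(Nc4nccc(-c5ccccc5)n4)c3)cc(N3CCN(C)CC3)c2)cn1` gives 2.16 h, and compound 3 `Cc1cn(-c2cc(CN3CCN(C)CC3)cc(NC(=O)c3ccc(C)c(Nc4nccc(-c5ccccc5)n4)c3)c2)cn1` gives 2.66 h. On these numbers compound 3 stands beyond the scatter above compound 1, as a 2.2-fold higher number from compound 1 to compound 3 (0.35 log units; beyond the scatter) shows, while its gap to compound 2 is within the scatter, as a 1.2-fold higher number from compound 2 to compound 3 (0.09 log units; within the scatter) shows; the step of a 1.8-fold higher number from compound 1 to compound 2 (0.26 log units; within the scatter) is likewise within the scatter.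

Compound 4 `Cc1cn(-c2cc(CCS(N)(=O)=O)cc(NC(=O)c3ccc(C)c(Nc4nccc(-c5ccccc5)n4)c3)c2)cn1` differs from compound 3 in one place: sulfamoylmethyl in place of 4-methylpiperazin-1-yl on a saturated chain carbon bound to an aromatic carbon. Among the compounds with values here, none of the measured steps touches a sulfonamide; all three concern the piperazine and its methyl or the methylene that carries it, and each of them was small. The change to compound 4 removes the piperazine altogether, so the measured steps bear on it only loosely, and no step beyond the scatter is expected in either direction, with a slight lean toward a shorter-lived compound.

The value of compound 4 in this assay is therefore estimated at 2 h, with a range from 1 h to 4 h, which corresponds to an expected step of a 1.3-fold lower number from compound 3 to compound 4 (0.12 log units; within the scatter).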

Compound 4, mean residence time: 0.239 h
Beside the measured number, compound 4's estimate is 8.4-fold (0.92 log units) above it, and the stated range ends above it.
By their numbers in this assay, from the lowest: compound 4; then compounds 1, 2 and 3 (each within the scatter of the next, the first and the last beyond it).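

In this assay the exchange of 4-methylpiperazin-1-yl for sulfamoylmethyl, on a saturated chain carbon bound to an aromatic carbon, gives the first large step seen at this position, an 11-fold lower number from compound 3 to compound 4 (1.05 log units; beyond the scatter), whereas the earlier changes to the piperazine and its link were all far smaller. The fall also holds against the two compounds with the piperazine ring bound directly to an aromatic carbon, with a 9.0-fold lower number from compound 2 to compound 4 (0.96 log units; beyond the scatter) and a 5.0-fold lower number from compound 1 to compound 4 (0.70 log units; beyond the scatter), so compound 4 has the shortest residence time of the four, and the read-out at this position proves far more sensitive to replacing the piperazine than to the earlier changes around it. Nothing available here accounts for the size of this fall.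

Since the ring leaves as the sulfonamide enters, the compounds shown cannot tell whether the loss of the piperazine or the arrival of the sulfamoyl group sets the low number. A morpholine or a dimethylamino group on the same chain carbon, or a methylsulfonyl group in place of the sulfamoyl group, would begin to separate the two.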